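Dichloro- and methylamino-methylsulfanyl quinolinediones: next sulfoxide step

A few compounds are considered here, and "the series" means these few. Any claim that something is new, unique, unknown or untested is made for them only; others in the source may bear on it.

Measured compounds in a functional assay on HL-60 cells (Homo sapiens) for antiproliferative activity, read by MTT assay, with a stated time of 48 h; a lower number here means a stronger inhibitor, a higher number a weaker inhibitor:
- compound 1 `O=C1C(Cl)=C(Cl)C(=O)c2ncccc21`: 31800 nM
- compound 2 `Cc1ccc2c(n1)C(=O)C(Cl)=C(Cl)C2=O`: 18700 nM
- compound 3 `CNC1=C(SC)C(=O)c2ncccc2C1=O`: 3440 nM

Compound 3 stands lowest of the three numbers in this assay; its nearest neighbour is compound 2, and compound 1 lies furthest, both gaps beyond the scatter. Within the data shown here, the one step, a 1.7-fold lower number from compound 1 to compound 2 (0.23 log units; within the scatter), is within the scatter and concerns the core substitution, not the groups on the non-aromatic ring.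

Compound 4 `CNC1=C([S+](C)[O-])C(=O)c2ncccc2C1=O` differs from compound 3 by a group of 3 heavy atoms (1 carbon, 1 oxygen, 1 sulfur; no ring) in place of a group of 2 heavy atoms (1 carbon, 1 sulfur; no ring), on a double-bonded ring carbon, on a double-bonded ring carbon of a six-membered non-aromatic ring of carbon only, part of a fused system of two rings. Among the measured compounds shown here, no measured step touches this exchange: the series holds no pair that swaps a methylsulfanyl for an oxidised sulfur group. The expectation can therefore rest only on compound 3 giving the lowest number, 3440 nM, and on the absence of any bearing step, so a step of modest size in either direction, not clearly beyond the scatter, is expected. For compound 4 in this assay the estimate is 5000 nM, with a range from 1500 nM to 16000 nM, which amounts to an expected step of a 1.5-fold higher number from compound 3 to compound 4 (0.16 log units; within the scatter).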

Compound 4, half-maximal inhibitory concentration: 12100 nM
Beside the measured number, compound 4's estimate is 2.4-fold (0.38 log units) below it, within the range that was stated.
By their numbers in this assay, from the lowest: compound 3; then compounds 4, 2 and 1 (each within the scatter of the next, the first and the last beyond it).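

In this assay, the exchange of methylsulfanyl for its oxidised sulfur counterpart, on a double-bonded ring carbon of the six-membered non-aromatic ring, gives a 3.5-fold higher number from compound 3 to compound 4 (0.55 log units; beyond the scatter). Among these compounds, this is the first step to touch this position, and unlike the methyl step on the aromatic carbon, it lies beyond the scatter. The position is therefore not indifferent to the state of the sulfur, at least with the methylamino group held constant, although nothing at hand bears on why the number rises.

Going by these compounds, whether a sulfone, with a second oxygen on the sulfur, would extend this rise remains open, as does the reading for a longer thioether such as ethylsulfanyl. Also open, on these data alone, is whether the same exchange gives a similar step with dimethylamino or morpholine in place of the methylamino group.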